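Ring and open chain on the amine nitrogen

The compounds below may be only part of what the source reports. "The series", "measured", "known", "first", "only" and "open" are said of these compounds alone.

Measured in an ADME assay on the whole organism (Rattus norvegicus), at a dose of 1 mg/kg by the intravenous route; a lower number here means less compound in the circulation, a higher number more compound in the circulation at the dose given:
- compound 1 `Cc1c(-c2ccc3c(c2)OCCO3)cccc1C(F)(F)Oc1cc(OCc2cncc(C#N)c2)c(CNC(CO)(CO)CO)cc1Cl`: 188 ng.h/mL
- compound 2 `Cc1c(-c2ccc3c(c2)OCCO3)cccc1C(F)(F)Oc1cc(OCc2ccnc(C#N)c2)c(CN2CCCC[C@H]2C(=O)O)cc1Cl`: 117 ng.h/mL
- compound 3 `Cc1c(-c2ccc3c(c2)OCCO3)cccc1C(F)(F)Oc1cc(OCc2ccnc(C#N)c2)c(CN[C@@H]2C(O)O[C@H](CO)[C@@H](O)[C@@H]2O)cc1Cl`: 464 ng.h/mL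

Compound 3 stands highest of the three, at 464 ng.h/mL. Compound 4 `Cc1c(-c2ccc3c(c2)OCCO3)cccc1C(F)(F)Oc1cc(OCc2ccnc(C#N)c2)c(CN[C@@H](CO)[C@@H](O)[C@@H](O)[C@H](O)CO)cc1Cl` has not yet been measured. It carries a group of 11 heavy atoms (6 carbon, 5 oxygen; no ring) in place of a group of 11 heavy atoms (6 carbon, 5 oxygen; one six-membered non-aromatic ring with 1 hetero atom), on an amine nitrogen, so the group that enters has no ring. Among the compounds with values here, the one measured step at this part of the molecule is a 4.0-fold higher number from compound 2 to compound 3 (0.60 log units; beyond the scatter), modest but beyond the scatter. It does not compare a ring with an open chain. Compound 1 also has a ring-free group there and gives 188 ng.h/mL, but it differs from compound 3 elsewhere too. The expected change is therefore small and towards a lower number, and may stay within the scatter: a 1.5-fold lower number from compound 3 to compound 4 (0.16 log units; within the scatter). Compound 4 is estimated at 320 ng.h/mL, with an expected range of 140 ng.h/mL to 700 ng.h/mL.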

Compound 4, area under the concentration-time curve: 141 ng.h/mL
Compound 4: the middle estimate sits 2.3-fold (0.36 log units) above what was measured; measured number inside the range.
By their numbers in this assay, from the lowest: compounds 2, 4 and 1 (each within the scatter of the next); then compound 3.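

In this assay, within the data shown here, replacing the ring with the open chain gives a 3.3-fold lower number from compound 3 to compound 4 (0.52 log units; beyond the scatter) at an equal count of heavy atoms, the first direct comparison of ring and open chain at this place, and it shows that the ring itself matters here. The open-chain group also gives a 1.2-fold higher number from compound 2 to compound 4 (0.08 log units; within the scatter) and so does not share the separation from compound 2 that compound 3 showed. Open, as far as these compounds go, is how an open chain ending in a carboxylic acid, or a smaller ring carrying hydroxyl groups, would behave on the amine nitrogen. Nothing available bears on the reason for the gap between ring and open chain.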